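The source may report more compounds than this note shows. Statements on the series, on what has been measured and on what is new or still open speak of the compounds shown alone.

Measured so far:
Compound 1, `CCNC(=O)Nc1cccc2c1CN(C)CC2c1ccccc1`, in a functional assay on the whole organism for inhibition of sodium-dependent dopamine transporter (Mus musculus) (a lower number here means that less compound is needed, a higher number that more compound is needed for the effect), gives > 80 mg/kg; this is a limit of the assay and not a number (the limit of > 80 mg/kg in this assay, at which 1 of the 2 values shown sits).
Compound 2, `CCOC(=O)Nc1cccc2c1CN(C)CC2c1ccccc1`, in this assay gives 2.5 mg/kg.

Among the compounds with values here, compound 2 thus holds the only real number in this assay; the other value is a limit. Compound 3, `CCCCOC(=O)Nc1cccc2c1CN(C)CC2c1ccccc1`, arises from compound 2 by ethyl in place of hydrogen on a saturated chain carbon, two bonds along the chain from an oxygen next to a carbonyl group. Within the data shown here, the one measured step, an at least 32-fold lower number from compound 1 to compound 2 (1.50 log units; beyond the scatter), swapped the group on the carbonyl carbon and so concerns a different place than the chain end; it gives no direct guide to the present change. Among the measured compounds shown here, no measured step bears on lengthening the chain. A step within the usual scatter is therefore the plainest expectation: compound 3 is expected to show a 1.2-fold higher number from compound 2 to compound 3 (0.08 log units; within the scatter). For compound 3 the estimate in this assay is 3 mg/kg, with a range from 1 mg/kg to 10 mg/kg.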

Compound 3, dose for half-maximal effect: 12 mg/kg
Beside the measured number, compound 3's estimate is 4.0-fold (0.60 log units) below it; the whole stated range lies below it.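

Going from ethoxy to butoxy in this assay gives a 4.8-fold higher number from compound 2 to compound 3 (0.68 log units; beyond the scatter), so the far end of this chain is not a neutral place: adding ethyl there raises the dose needed. Butoxy in place of ethylamino on the carbonyl carbon still gives an at least 6.6-fold lower number from compound 1 to compound 3 (0.82 log units; beyond the scatter), which means that compound 3, despite its longer chain, keeps a clear lead over the ethylamino compound. The value for compound 1 is a limit of the assay and not a number: the limit of > 80 mg/kg in this assay, at which 1 of the 3 values shown sits.

With only ethoxy and butoxy to compare on this oxygen, the compounds shown cannot say why the number rises, or whether it rises steadily as the chain grows. On these data alone, how a methoxy, a propoxy or a branched isopropoxy group would behave here remains open.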